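The source may report more compounds than this note shows. Statements on the series, on what has been measured and on what is new or still open speak of the compounds shown alone.

Compound 3 `Cc1cc(NC(=O)Cn2nnc(-c3ccccc3F)n2)n(C2CCCCC2)n1` is one of three compounds characterized in an assay on HEK293 cells for activation of Kir3.1/Kir3.2 (Homo sapiens), read by thallium flux; on this read-out lower numbers stand for smaller maximal responses and higher numbers for larger maximal responses. In this assay compound 3 gives 88%. Of the two numerical results this is the lower one: compound 1 `Cc1cc(NC(=O)Cn2nnc(-c3ccccc3)n2)n(C(C)C)n1` gives 107% in this assay, a result above that of compound 3 by a margin beyond the usual scatter. Compound 2 `Cc1nc(-c2ccccc2)c(NC(=O)Cn2nnc(-c3ccccc3)n2)s1` is reported in this assay as "not active" (no number reported), with no number attached. Compound 4 `Cc1cc(NC(=O)Cn2nnc(-c3ccc(Cl)c(C)c3)n2)n(C2CCCCC2)n1` has not yet been measured in this assay. It differs from compound 3 in one place: 4-chloro-3-methylphenyl in place of 2-fluorophenyl on an aromatic carbon. For the measured compounds named here, no measured pair among the three compounds shows what such a change does, so the data give no direction for the step. The expected step is therefore small, a number 3 percentage points lower from compound 3 to compound 4 (within the scatter), with no clear direction beyond the scatter. Compound 4 is accordingly estimated at 85%, with a range from 55% to 110%.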

Compound 4, largest response reached (Emax), in percent of the reference or control that the assay uses: 89%
Beside the measured number, compound 4's estimate is 4 percentage points below it; the measured number falls inside the stated range.
By their numbers in this assay, from the lowest: compounds 3 and 4 (each within the scatter of the next); then compound 1.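

For the compounds shown here, the pair gives the first one-place comparison in this set: with 4-chloro-3-methylphenyl in place of 2-fluorophenyl on this aromatic carbon, this assay shows a number 1 percentage points higher from compound 3 to compound 4 (within the scatter). At this position, the two substituted phenyl groups are therefore not told apart by maximal response. Nothing available here offers an explanation for this result. Still open, from the compounds shown here alone, is whether a group other than a substituted phenyl on this carbon, such as an amine, a carboxylic acid or a longer alkyl chain, would preserve the response.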